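A few compounds are considered here, and "the series" means these few. Any claim that something is new, unique, unknown or untested is made for them only; others in the source may bear on it.

Measured so far:
Compound 1, `O=C1Nc2ccc(C(=O)c3ccco3)cc2/C1=C/c1cc(F)c(O)c(F)c1`: 21%
Compound 2, `O=C1Nc2ccc(C(=O)c3ccco3)cc2/C1=C/c1cc(I)c(O)c(I)c1`: 26%

Among the measured compounds shown here, in an assay on HeLa cells for inhibition of Kinesin-like protein KIF15 (Homo sapiens), read by microscopy, with stated times of 2 s and 20 s, tested at 750 nM (a higher number here means more inhibition at the concentration tested (going by the name of the read-out), a lower number less inhibition), compound 2 has the higher of the two numbers, but the only measured step, a number 5 percentage points higher from compound 1 to compound 2 (within the scatter), is within the scatter, so the two compounds cannot be told apart. Compound 3, `O=C1Nc2ccc(C(=O)c3ccco3)cc2/C1=C/c1cc(F)c(O)c(Br)c1`, differs from compound 2 by a group of 9 heavy atoms (6 carbon, 1 oxygen, 1 fluorine, 1 bromine; one six-membered aromatic ring of carbon only) in place of a group of 9 heavy atoms (6 carbon, 1 oxygen, 2 iodine; one six-membered aromatic ring of carbon only), on a double-bonded chain carbon bound to a double-bonded ring carbon. For the measured compounds named here, the one relevant step swaps the same ring between two halogen pairs and stays within the scatter, so no step beyond the scatter is expected here either. For compound 3 the expected step is a number 3 percentage points lower from compound 2 to compound 3 (within the scatter). Compound 3 is therefore estimated at 23%, with a range from 10% to 36%.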

Compound 3, a percentage reported as inhibition, at one concentration (the size of the read-out at that concentration, not a potency): 38%
The estimate for compound 3 lay 15 percentage points below the measured number, outside the stated range (above it).
By their numbers in this assay, from the lowest: compounds 1 and 2 (each within the scatter of the next); then compound 3.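

In this assay, the ring carrying one fluoro and one bromo group gives a number 12 percentage points higher from compound 2 to compound 3 (beyond the scatter), and bromo in place of fluoro on an aromatic carbon gives a number 17 percentage points higher from compound 1 to compound 3 (beyond the scatter). Compound 1 and compound 2 alone suggested that swapping halogens on this ring changed little, but the mixed ring now stands apart from both, by modest steps. Nothing available explains this rise.

From the compounds shown here alone, it remains open whether the bromo group or the mixed pair matters, as a ring with two bromo groups would help to show. Going by these compounds, how a chloro group, or a methoxy group in place of the hydroxy group, would fare also stays unknown.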